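The source may hold more compounds than are shown below. What is called first, only, known or untested is meant among the compounds shown, and "the series" means these compounds.

Compound 1 `Nc1ccccc1NC(=O)c1ccc(CSC(=S)N2CCN(Cc3ccncc3)CC2)cc1` in a functional assay on A-375 cells (Homo sapiens) for antiproliferative activity, read by CCK-8 assay, with a stated time of 72 h, tested at 8 uM; on this read-out lower numbers stand for a weaker effect and higher numbers for a stronger effect at the one concentration tested: 89.5%
Compound 2 `Nc1ccccc1NC(=O)c1ccc(CSC(=S)N2CCN(c3ncccn3)CC2)cc1` in this assay: 67.9%

Among the compounds with values here, compound 2 stands lowest of the two numbers; its nearest neighbour is compound 1, and the only measured step is a number 21.6 percentage points lower from compound 1 to compound 2 (beyond the scatter). Compound 3 `Nc1ccccc1NC(=O)c1ccc(CSC(=S)N2CCN(C3CCCCC3)CC2)cc1` is not yet measured; it differs from compound 2 by cyclohexyl in place of pyrimidin-2-yl on an amine nitrogen in a ring. Within the data shown here, no measured step concerns this change: the step from compound 1 to compound 2 involves a different group and gives no direction for it. Without a bearing step, no shift beyond the scatter is expected, so the estimated step is a number 2.1 percentage points higher from compound 2 to compound 3 (within the scatter). Compound 3 is therefore estimated at 70%, with a range from 50% to 88%.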

Compound 3, a percentage reported as inhibition, at one concentration (the size of the read-out at that concentration, not a potency): 89.9%
Estimate against measurement, compound 3: 19.9 percentage points below; the measured number lies above the stated range.
By their numbers in this assay, from the lowest: compound 2; then compounds 1 and 3 (each within the scatter of the next).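

In this assay, the amine nitrogen in a ring accepts a group of carbon only: cyclohexyl in place of pyrimidin-2-yl gives a number 22 percentage points higher from compound 2 to compound 3 (beyond the scatter). Cyclohexyl in place of (pyridin-4-yl)methyl gives a number 0.4 percentage points higher from compound 1 to compound 3 (within the scatter), so among these compounds neither an aromatic ring nor a hydrogen-bond acceptor in this group is needed for the higher level, and compound 2 alone stands apart. Nothing measured gives a cause for either step.
Open, on these data alone, is whether phenyl on this nitrogen, a six-membered ring of carbon only but aromatic, would stand with compound 3 or with compound 2. Also open, as far as these compounds go, is whether an open chain such as n-butyl would hold that level.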